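Sulfonate ester series: amide to urea step on compound 1

The compounds below may be only part of what the source reports. "The series", "measured", "known", "first", "only" and "open" are said of these compounds alone.

Measured compounds in a functional assay on MCF7 cells (Homo sapiens) for antiproliferative activity, read by sulforhodamine B assay, with a stated time of 48 h; on this read-out lower numbers stand for stronger inhibition and higher numbers for weaker inhibition:
compound 1 `CCCC(=O)Nc1ccc(S(=O)(=O)Oc2ccccc2C(C)C)cc1`, 6600 nM;
compound 2 `CCCC(=O)Nc1ccc(S(=O)(=O)Oc2ccccc2I)cc1`, 9700 nM;
compound 3 `O=C(Nc1ccc(S(=O)(=O)Oc2ccccc2I)cc1)NC1CC1`, 7400 nM.

The three measured numbers lie within the scatter of one another: the step of a 1.5-fold higher number from compound 1 to compound 2 (0.17 log units; within the scatter) and the step of a 1.3-fold lower number from compound 2 to compound 3 (0.12 log units; within the scatter) are both within the scatter, and compound 1 and compound 3 are likewise within the scatter of each other, so nothing separates compound 1 from the other two on the numbers shown.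

Compound 4 `CC(C)c1ccccc1OS(=O)(=O)c1ccc(NC(=O)NCC2CCCC2)cc1` differs from compound 1 in one place: (cyclopentylmethyl)amino in place of propyl on a carbonyl carbon. The change keeps the aryl ring with its isopropyl group from compound 1 and converts the amide into a urea, as was done in the step from compound 2 to compound 3, where a cyclopropylamino group replaced propyl on the carbonyl carbon. That step, a 1.3-fold lower number from compound 2 to compound 3 (0.12 log units; within the scatter), stayed within the scatter. Among the compounds with values here, the present change installs a larger (cyclopentylmethyl)amino group, for which no measured step exists; the only bearing comparison is the amide-to-urea step just named. In this assay a step within the scatter is therefore expected, a 1.2-fold lower number from compound 1 to compound 4 (0.08 log units; within the scatter). Compound 4 is estimated at 5500 nM, in the range 2500 nM to 12000 nM.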

Compound 4, half-maximal inhibitory concentration: 7100 nM
The estimate for compound 4 lay 1.3-fold (0.11 log units) below the measured number; measured number inside the range.
By their numbers in this assay, from the lowest: compounds 1, 4, 3 and 2 (each within the scatter of the next).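

On the carbonyl carbon of compound 1, (cyclopentylmethyl)amino in place of propyl gives, in this assay, a 1.1-fold higher number from compound 1 to compound 4 (0.03 log units; within the scatter), so this position accepts a group with a five-membered non-aromatic ring of carbon only and a hydrogen-bond donor without a step beyond the scatter. The earlier urea step, with cyclopropylamino on the iodo compounds, did not show this for a larger group or with the isopropyl group kept on the aryl ring. No measurement shown gives a reason for this result.

Open, going by these compounds, is whether a group on this carbonyl carbon can move the number beyond the scatter at all. A terminal amine, a carboxylic acid or a longer chain in place of cyclopentylmethyl would test this.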